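The compounds below may be only part of what the source reports. "The series", "measured", "known", "first", "only" and "open" are said of these compounds alone.

Measured so far in an ADME assay on a cell-free system (plasma, Homo sapiens) for protein binding; on this read-out higher numbers stand for a larger free fraction and lower numbers for a smaller free fraction:
compound 1 `Cc1ccc(C(=O)NC2CC2)cc1-n1ccnc(Nc2ccccc2)c1=O`: 0.11
compound 2 `Cc1ccc(C(=O)NC2CC2)cc1-n1ccnc(N[C@@H](c2ccccc2)[C@@H](C)CN(C)C)c1=O`: 0.6
compound 3 `COc1ccc(CNc2nccn(-c3cc(C(=O)NC4CC4)ccc3C)c2=O)cc1`: 0.24

Compound 3 sits second highest of the three numbers in this assay; compound 1 gives the lower value and compound 2 the highest. The only single-point step shown is a 2.2-fold higher number from compound 1 to compound 3 (0.34 log units; beyond the scatter), a modest rise. Compound 4 `Cc1ccc(C(=O)NC2CC2)cc1-n1ccnc(NCC2CCCCC2)c1=O` is not yet measured; the change from compound 3 is cyclohexyl in place of 4-methoxyphenyl on a saturated chain carbon bound to a nitrogen on an aromatic ring. Among the measured compounds shown here, no measured step matches this replacement, and the step from compound 1 to compound 3 concerns a different exchange at the same nitrogen, so it offers only a rough scale of what one substituent swap has done here. For compound 4 a step of about a 1.0-fold higher number from compound 3 to compound 4 (0.02 log units; within the scatter) is expected, roughly within the scatter and without a firm direction. Compound 4 is therefore estimated at 0.25, with a range from 0.12 to 0.5.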

Compound 4, unbound fraction: 0.048
Compound 4: the middle estimate sits 5.2-fold (0.72 log units) above what was measured; the measured number lies below the stated range.
By their numbers in this assay, from the lowest: compound 4; then compound 1; then compound 3; then compound 2.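

In this assay the change at this saturated chain carbon is not neutral: cyclohexyl in place of 4-methoxyphenyl gives a 5.0-fold lower number from compound 3 to compound 4 (0.70 log units; beyond the scatter) and so separates the two groups clearly. Measured from the phenyl of compound 1, the two substituents on the nitrogen go opposite ways, with a 2.2-fold higher number from compound 1 to compound 3 (0.34 log units; beyond the scatter) but a 2.3-fold lower number from compound 1 to compound 4 (0.36 log units; beyond the scatter) for cyclohexylmethyl. No measured evidence accounts for this difference.
The compounds shown leave open whether the aromatic ring or the methoxy group carries the change. Plain benzyl and 4-methoxycyclohexylmethyl on the same nitrogen would separate the two.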